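Phenethyl in place of naphthalen-1-yl on a sulfur

The source may hold more compounds than are shown below. What is called first, only, known or untested is meant among the compounds shown, and "the series" means these compounds.

Measured in a functional assay on HCT-116 cells (Homo sapiens) for inhibition, read by CCK-8 assay, with a stated time of 72 h, tested at 2 uM (on this read-out higher numbers stand for more inhibition of growth at the one concentration tested and lower numbers for less inhibition of growth), so far:
- compound 1 `Nc1ccccc1NC(=O)/C=C/c1ccc(CSc2ccc(C(F)(F)F)cn2)cc1` gives 4.42%
- compound 2 `Nc1ccccc1NC(=O)/C=C/c1ccc(CSc2cccc3ccccc23)cc1` gives 11%

These two numbers cannot be told apart, so compound 2 stands level with compound 1. Among the compounds with values here, the only measured step is a number 6.6 percentage points higher from compound 1 to compound 2 (within the scatter) and it swapped a different pair of groups on the sulfur. Compound 3 `Nc1ccccc1NC(=O)/C=C/c1ccc(CSCCc2ccccc2)cc1` carries phenethyl in place of naphthalen-1-yl on a sulfur, a change counted as phenethyl in place of naphthalen-1-yl on a sulfur in full. Within the data shown here, with that single small step as the only guide, no step beyond the scatter is expected in this assay in either direction. The estimate is a number 2 percentage points lower from compound 2 to compound 3 (within the scatter) as the expected move. For compound 3 the expected value is 9% (0% to 22%).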

Compound 3, percent growth inhibition at one concentration: 18%
Compound 3: middle estimate off by 9 percentage points, on the low side; the range from low to high includes it.
By their numbers in this assay, from the lowest: compounds 1, 2 and 3 (each within the scatter of the next, the first and the last beyond it).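

In this assay, within the data shown here, phenethyl is the first group here that joins the sulfur through a chain rather than directly through an aromatic ring. Among these compounds, replacing naphthalen-1-yl with it gives a number 7 percentage points higher from compound 2 to compound 3 (within the scatter), while replacing 5-(trifluoromethyl)pyridin-2-yl with it gives a number 13.6 percentage points higher from compound 1 to compound 3 (beyond the scatter), the first step beyond the scatter, though a modest one. No measurement shown here explains this difference.

On these data alone, it remains open whether a longer chain would shift growth inhibition further. The same question applies to a chain ending in an amine or a carboxylic acid in this place.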